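Three limits and a fluorinated methoxyphenyl newcomer

A few compounds are considered here, and "the series" means these few. Any claim that something is new, unique, unknown or untested is made for them only; others in the source may bear on it.

Compound 1 `CC(C)COc1cccc(-c2ccc(C(=O)N(Cc3cccc(OCCCCCC(=O)O)c3)C(C)C)cc2)c1`: in an ADME assay on BJ cells (Homo sapiens) for cytotoxicity, read by CellTiter-Glo and resazurin assay, with a stated time of 72 h (a higher number here means that more compound is needed for the effect, a lower number that less compound is needed), compound 1 gives > 26000 nM, a limit of the assay.
Compound 2 `CC(C)N(Cc1cccc(OCCCCCC(=O)O)c1)C(=O)c1ccc(-c2ccsc2)cc1`: in this assay compound 2 gives > 26000 nM, a limit of the assay.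
Compound 3 `COc1cc(OC)cc(-c2ccc(C(=O)N(Cc3cccc(OCCCCCC(=O)O)c3)C(C)C)cc2)c1`: in this assay compound 3 gives > 26000 nM, a limit of the assay.

Compound 3 therefore stands only at a limit, and the two other values shown stand at the same limit (the limit of > 26000 nM in this assay, at which 3 of the 3 values shown sit). The change to compound 4 `COc1ccc(F)c(-c2ccc(C(=O)N(Cc3cccc(OCCCCCC(=O)O)c3)C(C)C)cc2)c1` is 2-fluoro-5-methoxyphenyl in place of 3,5-dimethoxyphenyl on an aromatic carbon. The measured steps that bear on it are a step that the two limits leave unreadable from compound 1 to compound 2, a step that the two limits leave unreadable from compound 1 to compound 3 and a step that the two limits leave unreadable from compound 2 to compound 3; none of them can be read in size, since every value sits at the limit. The three variations at this aromatic carbon left the read-out unchanged at the limit (the limit of > 26000 nM in this assay, at which 3 of the 3 values shown sit), so the step that the limit leaves unreadable from compound 3 to compound 4 is expected to be none beyond the scatter, with the result most likely reported again as a limit. Compound 4 is estimated at 30000 nM, with a range from 12000 nM to 80000 nM.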

Compound 4, half-maximal effective concentration: > 26000 nM
Compound 4 gave a limit, no number (the forecaster's own chance of this, stated with the estimate: 85%); the middle value is on the limit's open side.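

Compound 4 ends at a limit, as do compound 1, compound 2 and compound 3, so no step among them can be read in this assay: the limit of > 26000 nM in this assay, at which 4 of the 4 values shown sit.

The compounds shown leave open how far each lies beyond that limit, and whether any group at this aromatic carbon changes the read-out.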